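Removing the methoxy from the fused-ring amide of compound 2

This account rests on a few compounds, and the source may have more. Where it says the series, first, only, none or still open, it means among the compounds named here.

The set pairs a trifluoromethyl-bearing hydrated acid, linked through an alkyl chain amide to an aromatic amine, and is followed in a functional assay on HCT-116 cells (Homo sapiens) for inhibition, read by colorimetric assay, with a stated time of 3 days; on this read-out lower numbers stand for stronger inhibition and higher numbers for weaker inhibition. Compound 1 `O=C(CCCCCCNC(=O)C(O)C(F)(F)F)Nc1nccs1` reaches only the limit of this assay, > 40000 nM; that limit is the one recorded as the limit of > 40000 nM in this assay, at which 1 of the 3 values shown sits. Compound 2 `COc1ccc2sc(NC(=O)CCCCCCNC(=O)C(O)(O)C(F)(F)F)nc2c1` gives 2180 nM in this assay, the lowest of the two numbers reported. Compound 3 `O=C(CCCCNC(=O)C(O)(O)C(F)(F)F)Nc1ccccc1` gives 20300 nM in this assay, a higher number than that of compound 2 and beyond the scatter.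

Compound 4 `O=C(CCCCCCNC(=O)C(O)(O)C(F)(F)F)Nc1nc2ccccc2s1` differs from compound 2 in one place only: hydrogen in place of methoxy on an aromatic carbon. Within the data shown here, no measured pair in the set shows this change, so the size of its step is open. The methoxy is the sole substituent on the shared core of compound 2, and its removal is expected to bring a small loss, or none beyond the scatter. The step is estimated as a 1.6-fold higher number from compound 2 to compound 4 (0.21 log units; within the scatter). Compound 4 is accordingly expected to give 3500 nM in this assay, with a range from 1400 nM to 9000 nM.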

Compound 4, half-maximal inhibitory concentration: 2370 nM
Compound 4: middle estimate off by 1.5-fold (0.17 log units), on the high side; the measured number falls inside the stated range.
By their numbers in this assay, from the lowest: compounds 2 and 4 (each within the scatter of the next); then compound 3. At a limit, above all of these: compound 1.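

In this assay the series gains its first step in one place, a 1.1-fold higher number from compound 2 to compound 4 (0.04 log units; within the scatter), with hydrogen in place of methoxy on an aromatic carbon of a six-membered aromatic ring of carbon only. Within the scatter, the two compounds cannot be told apart, so at this position the methoxy can be exchanged for hydrogen with no discernible consequence for this read-out. Nothing given here bears on the reason for this result.

On these data alone, whether an amine, a carboxylic acid or a larger group such as a phenyl ring would be tolerated equally at this carbon remains open, as does the same exchange at other carbons of the ring. As far as these compounds go, compound 1 and compound 3 each differ from compound 4 in more than one place, so the separate contributions of chain and core also remain open.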